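Adding Two Methoxy Groups to a Ring Already Seen to Hurt

The compounds below may be only part of what the source reports. "The series", "measured", "known", "first", "only" and "open" are said of these compounds alone.

Compound 1 `COc1ccc(C2=NN(C(=O)c3cccnc3)C(c3cn(C)c4ccc(Br)cc34)C2)cc1` carries a 4-methoxyphenyl group on its shared core. In a functional assay on A549 cells (Homo sapiens) for inhibition, read by MTT assay, with a stated time of 48 h (a higher number here means a weaker inhibitor of growth, a lower number a stronger inhibitor of growth), compound 1 gives 1190 nM. Compound 2 `COc1cc(C2=NN(C(=O)c3cccnc3)C(c3cn(C)c4ccc(Br)cc34)C2)cc(OC)c1OC` differs from compound 1 in one place, (3,4,5-trimethoxyphenyl in place of 4-methoxyphenyl on a carbon with a double bond to nitrogen), and the result is an at least 8.4-fold higher number from compound 1 to compound 2 (0.92 log units; beyond the scatter). The value of compound 2 in this assay is a limit of the assay rather than a number, > 10000 nM, because of the limit of > 10000 nM in this assay, at which 1 of the 3 values shown sits, so the true size of that step is known only as a floor.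

Compound 3 `COc1ccc(C2=NN(C(=O)c3ccc(OC)nc3)C(c3cn(C)c4ccc(OC)cc34)C2)cc1` sits on a core that differs from that of compound 1; the difference between the two cores is not broken down here. In this assay compound 3 gives 450 nM, the lowest of the two numbers recorded, with compound 1 as its nearest neighbour.

Compound 4 `COc1ccc2c(c1)c(C1CC(c3cc(OC)c(OC)c(OC)c3)=NN1C(=O)c1ccc(OC)nc1)cn2C` has not yet been measured. Going by the values given here, it differs from compound 3 in the same kind of change as the one from compound 1 to compound 2: 3,4,5-trimethoxyphenyl in place of 4-methoxyphenyl on a carbon with a double bond to nitrogen. The surroundings are not identical, since the ring atom two ring bonds away bears a (6-methoxypyridin-3-yl)carbonyl group in compound 3 and compound 4, whereas it bears a (pyridin-3-yl)carbonyl group in compound 1 and compound 2.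

Because the earlier change produced an at least 8.4-fold higher number from compound 1 to compound 2 (0.92 log units; beyond the scatter), a step of comparable size is expected here, namely an 8.9-fold higher number from compound 3 to compound 4 (0.95 log units; beyond the scatter). Compound 4 is therefore estimated to give 4000 nM in this assay, with a likely span from 1200 nM to 12000 nM, and there is a real chance that only a limit of the assay is reported.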

Compound 4, concentration for 50% growth inhibition: > 10000 nM
Compound 4 gave a limit, no number; the forecaster's own chance of this, stated with the estimate: 35%; middle value at least 2.5-fold (0.39 log units) away from the limit.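

In this assay, putting 3,4,5-trimethoxyphenyl in place of 4-methoxyphenyl raises the number again on the core of compound 3, with an at least 22-fold higher number from compound 3 to compound 4 (1.34 log units; beyond the scatter), so the direction seen on the core of compound 1 carries over to this second pair, and both pairs shown lose growth inhibition with this change. Compound 4 gives > 10000 nM, which is a limit of the assay and not a number, so the size of this step is known only as a floor. What the pair does not show is whether the change costs more on one core than on the other, and two pairs are too few to say how it would behave on other cores: the same change on two cores in this assay, an at least 8.4-fold higher number (0.92 log units; beyond the scatter) from compound 1 to compound 2 and an at least 22-fold higher number (1.34 log units; beyond the scatter) from compound 3 to compound 4; the limit leaves it open whether they differ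

Going by these compounds alone, each pair goes directly from 4-methoxyphenyl to 3,4,5-trimethoxyphenyl, which leaves open whether a phenyl ring carrying only two methoxy groups would already lose as much growth inhibition. Also open, going by these compounds, is how a plain phenyl ring, or a phenyl ring carrying a hydroxyl group or an amine in place of the methoxy group, would read in this assay on either core.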